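Cytotoxicity notes on a pyrrolopyrimidine-type series with hydroxyethoxymethyl chain

The compounds below may be only part of what the source reports. "The series", "measured", "known", "first", "only" and "open" are said of these compounds alone.

Measured so far:
compound 1 `CSc1nc(Cl)c2ccn(COCCO)c2n1`, > 100000 nM
compound 2 `CSc1nc(N)c2ccn(COCCO)c2n1`, > 100000 nM
compound 3 `Nc1nc(Cl)nc2c1ccn2COCCO`, > 100000 nM

In a functional assay on BSC-1 cells (Cercopithecidae) for cytotoxicity (a lower number here means a stronger inhibitor, a higher number a weaker inhibitor), compound 1 gives only a limit of the assay, > 100000 nM. Compound 2 likewise reaches only the limit, > 100000 nM. Compound 3 again stops at the limit, > 100000 nM. All three values sit at the limit of > 100000 nM in this assay, at which 3 of the 3 values shown sit, so a step that the two limits leave unreadable from compound 1 to compound 2 and a step that the two limits leave unreadable from compound 2 to compound 3 cannot be read.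

Compound 4 `Nc1nc(N)c2ccn(COCCO)c2n1` is not yet measured. It differs from compound 3 by amino in place of chloro on an aromatic carbon. The change from compound 1 to compound 2 is amino in place of chloro on an aromatic carbon, the same kind of change, but at a place between two ring nitrogen atoms and meta to an amino group rather than next to the ring nitrogen and meta to a methylsulfanyl group. The difference between the two cores is not broken down here.

Since compound 3 gives only a limit, > 100000 nM, the step from compound 3 to compound 4 is expected to stay unreadable, a step that the limit leaves unreadable from compound 3 to compound 4. Compound 4 is expected to give 150000 nM, most likely reported again as a limit.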

Compound 4, half-maximal inhibitory concentration: > 100000 nM
Compound 4: a limit, no number; the forecaster's own chance of this, stated with the estimate: 85%; the middle value lies beyond the limit too.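

Compound 4 gives only the limit > 100000 nM and the steps to it from compound 2 and compound 3 cannot be read: the limit of > 100000 nM in this assay, at which 4 of the 4 values shown sit.

In this assay the compounds shown leave open which change to the shared core, if any, would give a value short of this limit.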